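The compounds below may be only part of what the source reports. "The series", "measured", "known", "first", "only" and "open" are said of these compounds alone.

Compound 1 `CCCS(=O)(=O)Nc1ccc(F)c(C(=O)c2n[nH]c3ncc(-c4cccc(F)c4)cc23)c1F` gives 8.2% in an assay for binding affinity to dual specificity mitogen-activated protein kinase kinase 4 (Homo sapiens), read by KINOMEscan, tested at 100 nM; on this read-out lower numbers stand for a stronger effect and higher numbers for a weaker effect at the one concentration tested.
Compound 2 `CCCS(=O)(=O)Nc1ccc(F)c(C(=O)c2n[nH]c3ncc(-c4ccc(F)cc4)cc23)c1F` gives 2.1% in this assay.
Compound 3 `CCCS(=O)(=O)Nc1ccc(F)c(C(=O)c2n[nH]c3ncc(-c4ccccc4C)cc23)c1F` gives 7% in this assay.

Compound 2 has the smallest of the three numbers, but nothing sets it apart: the step of a number 6.1 percentage points lower from compound 1 to compound 2 (within the scatter) and the step of a number 4.9 percentage points higher from compound 2 to compound 3 (within the scatter) both stay within the scatter, as does the step of a number 1.2 percentage points lower from compound 1 to compound 3 (within the scatter). All three measured steps exchange one substituted phenyl ring for another on the same aromatic carbon of the shared core, and none of them moves the read-out beyond the scatter.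

Compound 4 `CCCS(=O)(=O)Nc1ccc(F)c(C(=O)c2n[nH]c3ncc(-c4ccc(Cl)c(Cl)c4)cc23)c1F` carries the same kind of exchange: 3,4-dichlorophenyl in place of 4-fluorophenyl on an aromatic carbon. The three measured steps are the only ones that bear on it, and they suggest that swapping the substituents on this phenyl ring leaves the read-out in this assay essentially unchanged. The step from compound 2 to compound 4 is therefore expected to be small, a number 2.9 percentage points higher from compound 2 to compound 4 (within the scatter), with no direction beyond the scatter. For compound 4 the estimate in this assay is 5%, in the range 0.5% to 20%.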

Compound 4, a percentage reported as activity, at one concentration (the size of the read-out at that concentration, not a potency): 45%
For compound 4 the middle estimate is 40 percentage points below the measured one, and the stated range ends below it.
By their numbers in this assay, from the lowest: compounds 2, 3 and 1 (each within the scatter of the next); then compound 4.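

In this assay this position on the shared core proves not to be indifferent to what the phenyl ring carries: a number 42.9 percentage points higher from compound 2 to compound 4 (beyond the scatter) and a number 38 percentage points higher from compound 3 to compound 4 (beyond the scatter) and a number 36.8 percentage points higher from compound 1 to compound 4 (beyond the scatter) all stand as large steps. The 3-fluorophenyl, 4-fluorophenyl and 2-methylphenyl rings remain within the scatter of one another, so 3,4-dichlorophenyl is the only ring shown that separates from the rest, with a weaker effect at the one concentration tested. Nothing available explains why this exchange has so large an effect.

Compound 4 is the only one with chlorine, and the only one with two substituents on this ring, so these compounds cannot separate the two features. A 4-chlorophenyl, a 3-chlorophenyl or a 3,4-difluorophenyl ring at this position would show whether one chlorine is enough, or whether two fluorines would do the same.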